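This account rests on a few compounds, and the source may have more. Where it says the series, first, only, none or still open, it means among the compounds named here.

Measured compounds in a functional assay on PC-3 cells (Homo sapiens) for inhibition, read by sulforhodamine B assay, with a stated time of 48 h, tested at 10 uM; a higher number here means more inhibition of growth at the concentration tested, a lower number less inhibition of growth:
compound 1 `COc1cc(-c2nc(N)n(CC(=O)Nc3ccc(/C(C)=N\O)cc3)n2)cc(OC)c1OC`: 23.3%
compound 2 `C/C(=N/O)c1ccc(NC(=O)Cn2nc(-c3ccccc3)nc2N)cc1`: 15.8%
compound 3 `c1ccc(-c2nc3sc(-c4ccccc4)cn3n2)cc1`: 37%

Compound 2 gives the lowest of the three numbers, though compound 1 stands within the usual scatter of it, so no order between those two is claimed; only compound 3 lies beyond the scatter above compound 2. Compound 4 `C/C(=N/O)c1ccc(NC(=O)Cn2nc(C(F)(F)F)nc2N)cc1` differs from compound 2 by trifluoromethyl in place of phenyl on an aromatic carbon. Within the data shown here, no pair of measured compounds shows a step of this kind, so nothing measured tells how this change acts in this assay. The expected step is therefore a number 0.8 percentage points lower from compound 2 to compound 4 (within the scatter), none beyond the scatter in either direction. Compound 4 is accordingly estimated at 15%, with a range from 3% to 30%.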

Compound 4, percent growth inhibition at one concentration: 20.3%
Beside the measured number, compound 4's estimate is 5.3 percentage points below it, within the range that was stated.
By their numbers in this assay, from the lowest: compounds 2, 4 and 1 (each within the scatter of the next); then compound 3.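

In this assay this aromatic carbon now has its first step, a number 4.5 percentage points higher from compound 2 to compound 4 (within the scatter) for trifluoromethyl in place of phenyl. The six-membered aromatic ring can therefore leave this place with no change beyond the scatter, although this rests on a single pair read at one concentration. No measurement here offers an explanation for this result. On these data alone, it remains open whether an amine, a carboxylic acid or a longer chain on this carbon would read differently, and whether the same exchange would behave alike on compound 1.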